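Swapping 4-fluorophenyl for 2-chlorophenyl: expected solubility

A few compounds are considered here, and "the series" means these few. Any claim that something is new, unique, unknown or untested is made for them only; others in the source may bear on it.

Compound 1 `CCOC(=O)c1cc(-c2ccc(Cl)cc2)n(-c2ccc(S(N)(=O)=O)cc2)c1C`: 4200 nM
Compound 2 `CCOC(=O)c1cc(-c2ccc(F)cc2)n(-c2ccc(S(N)(=O)=O)cc2)c1C`: 12600 nM

In a physicochemical assay for solubility, read by HPLC, in phosphate buffer, measured as kinetic solubility, at pH 7.4 (on this read-out lower numbers stand for lower solubility and higher numbers for higher solubility), compound 2 gives 12600 nM, the highest of the two numbers; its nearest neighbour is compound 1 with 4200 nM. Among the compounds with values here, the single step in hand is a 3.0-fold higher number from compound 1 to compound 2 (0.48 log units; beyond the scatter). Compound 3 `CCOC(=O)c1cc(-c2ccccc2Cl)n(-c2ccc(S(N)(=O)=O)cc2)c1C` carries 2-chlorophenyl in place of 4-fluorophenyl on an aromatic carbon. Only part of this change is covered by that step, which returned chlorine in place of fluorine and ran the other way, so compound 3 is expected to fall back toward compound 1 rather than move beyond compound 2. Compound 3 is therefore estimated at 5000 nM, between 2000 nM and 15000 nM, a step of a 2.5-fold lower number from compound 2 to compound 3 (0.40 log units; beyond the scatter).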

Compound 3, solubility: 13700 nM
The estimate for compound 3 lay 2.7-fold (0.44 log units) below the measured number; the measured number falls inside the stated range.
By their numbers in this assay, from the lowest: compound 1; then compounds 2 and 3 (each within the scatter of the next).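

In this assay, 2-chlorophenyl in place of 4-fluorophenyl gives a 1.1-fold higher number from compound 2 to compound 3 (0.04 log units; within the scatter). Set against 4-chlorophenyl, the same group gives a 3.3-fold higher number from compound 1 to compound 3 (0.51 log units; beyond the scatter), so among these compounds a chlorine on the phenyl ring does not by itself go with the lowest number. Nothing in hand bears on what lies behind these steps. The compounds shown leave open how 2-fluorophenyl would compare with 2-chlorophenyl on this carbon. They also leave open whether an amine on that phenyl ring would move the number beyond the scatter.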